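Methyl for chloro on the fused core: compound 4

This account rests on a few compounds, and the source may have more. Where it says the series, first, only, none or still open, it means among the compounds named here.

Going by the values given here, compound 3 `CC(C)(C)c1cc(NC(=O)Nc2ccc(-c3cn4ccc(Cl)cc4n3)cc2)no1` gives the lowest number so far in a functional assay on MV4-11 cells (Homo sapiens) for cytotoxicity, read by MTT assay, with a stated time of 72 h (on this read-out lower numbers stand for stronger inhibition and higher numbers for weaker inhibition), 5.91 nM. Compound 2 `Cc1cccn2cc(-c3ccc(NC(=O)Nc4cc(C(C)(C)C)on4)cc3)nc12` gives 248 nM in this assay, and compound 1 `CC(C)(C)c1cc(NC(=O)Nc2ccc(-c3cn4cccc(Cl)c4n3)cc2)no1` gives 353 nM; both stand well above compound 3, beyond the scatter. Compound 4 `Cc1ccn2cc(-c3ccc(NC(=O)Nc4cc(C(C)(C)C)on4)cc3)nc2c1` differs from compound 3 by methyl in place of chloro on an aromatic carbon. The same exchange has been seen once, at a different place on the shared core: a 1.4-fold lower number from compound 1 to compound 2 (0.15 log units; within the scatter). On that basis no step beyond the scatter is expected from compound 3 to compound 4, with at most a slight move toward a lower number. Compound 4 is therefore expected to give about 5 nM, within a range of 1.5 nM to 20 nM, which means an expected step of a 1.2-fold lower number from compound 3 to compound 4 (0.07 log units; within the scatter).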

Compound 4, half-maximal inhibitory concentration: 0.79 nM
Estimate against measurement, compound 4: 6.3-fold (0.80 log units) above, outside the stated range (below it).
By their numbers in this assay, from the lowest: compound 4; then compound 3; then compounds 2 and 1 (each within the scatter of the next).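

In this assay methyl in place of chloro on this aromatic carbon, opposite the ring nitrogen, gives a 7.5-fold lower number from compound 3 to compound 4 (0.87 log units; beyond the scatter) and so moves the number beyond the scatter. The earlier exchange at a different place on the shared core did not, so the size of the step from this change differs with its place: the same change on two cores in this assay, a 1.4-fold lower number (0.15 log units; within the scatter) from compound 1 to compound 2 and a 7.5-fold lower number (0.87 log units; beyond the scatter) from compound 3 to compound 4, 5.3-fold (0.72 log units) apart, beyond the scatter of two such steps.

Going by these compounds, whether the step comes from adding methyl or from losing chloro remains open. On these data alone, what an amine or a methoxy group would give at this position also remains open.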